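Estimating a thiophene analogue from two close values

The source may report more compounds than this note shows. Statements on the series, on what has been measured and on what is new or still open speak of the compounds shown alone.

Measured so far in a functional assay on LOX IMVI cells (Homo sapiens) for cytotoxicity; a lower number here means a stronger inhibitor of growth, a higher number a weaker inhibitor of growth
Compound 1 `COc1ccccc1C#Cc1ccccc1C#CCCCCO` gives 17900 nM
Compound 2 `OCCCCC#Cc1ccccc1C#Cc1ccccn1` gives 27700 nM

Compound 2 stands level with compound 1, the two values lying within the usual scatter of each other. Compound 3 `OCCCCC#Cc1ccccc1C#Cc1cccs1` carries thiophen-2-yl in place of pyridin-2-yl on a triple-bonded carbon. For the measured compounds named here, no measured step shows what this exchange does in this assay, so only a small move toward a lower number, none beyond the scatter, is expected. The expected step is a 1.4-fold lower number from compound 2 to compound 3 (0.14 log units; within the scatter) in this estimate. Compound 3 is estimated at 20000 nM, with the result expected to fall between 8000 nM and 50000 nM when measured.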

Compound 3, concentration for 50% growth inhibition: 13900 nM
For compound 3 the middle estimate is 1.4-fold (0.16 log units) above the measured one; the measured number falls inside the stated range.
By their numbers in this assay, from the lowest: compounds 3, 1 and 2 (each within the scatter of the next).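

In this assay, putting thiophen-2-yl in place of pyridin-2-yl on a triple-bonded carbon gives a 2.0-fold lower number from compound 2 to compound 3 (0.30 log units; within the scatter). This first step read at this position shows that a five-membered aromatic ring with sulfur can replace a six-membered aromatic ring with nitrogen without a change beyond the scatter. No available measurement bears on the reason for this result. On these data alone, it remains open whether any group on this triple-bonded carbon can move the number beyond the scatter, for example an amine or a carboxylic acid.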